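The source may hold more compounds than are shown below. What is called first, only, known or untested is meant among the compounds shown, and "the series" means these compounds.

Measured in an assay on isolated protein for inhibition of Amine oxidase [flavin-containing] B (Homo sapiens), read by fluorescence and spectrophotometry, with a stated time of 20 min; a lower number here means a stronger inhibitor, a higher number a weaker inhibitor:
Compound 1 `O=C1/C(=C/c2cccc(F)c2)Cc2cc(O)ccc21` gives 84 nM.
Compound 2 `Cc1cccc(/C=C2\Cc3cc(O)ccc3C2=O)c1` gives 52 nM.
Compound 3 `N#Cc1cccc(/C=C2\Cc3cc(O)ccc3C2=O)c1` gives 130 nM.

Compound 3 holds the highest of the three numbers in this assay, but its gap to compound 1 lies within the scatter; only the gap to compound 2 is beyond it, as a 2.5-fold higher number from compound 2 to compound 3 (0.40 log units; beyond the scatter) shows. Compound 4 `O=C1/C(=C/c2cccc(O)c2)Cc2cc(O)ccc21` differs from compound 3 in one place: hydroxy in place of cyano on an aromatic carbon. Among the measured compounds shown here, no measured step brings in a hydroxy group anywhere, so the steps that bear on this change are only those at the same aromatic carbon: a 1.5-fold higher number from compound 1 to compound 3 (0.19 log units; within the scatter) and a 1.6-fold lower number from compound 1 to compound 2 (0.21 log units; within the scatter), together with the step from compound 2 to compound 3 already named. Fluoro, methyl and cyano at this position give numbers in a narrow band, with just one of the three steps beyond the scatter. A hydroxy group at the same place is expected to land inside or near that band, with no direction beyond the scatter predicted. For compound 4 the expected step is accordingly small, a 1.4-fold lower number from compound 3 to compound 4 (0.16 log units; within the scatter). Compound 4 is estimated at 90 nM, within a range from 35 nM to 250 nM.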

Compound 4, half-maximal inhibitory concentration: 966 nM
The estimate for compound 4 lay 11-fold (1.03 log units) below the measured number; the measured number lies above the stated range.
By their numbers in this assay, from the lowest: compounds 2, 1 and 3 (each within the scatter of the next, the first and the last beyond it); then compound 4.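

In this assay, the band formed by fluoro, methyl and cyano at this aromatic carbon does not extend to hydroxy, with a 7.4-fold higher number from compound 3 to compound 4 (0.87 log units; beyond the scatter), a 12-fold higher number from compound 1 to compound 4 (1.06 log units; beyond the scatter) and a 19-fold higher number from compound 2 to compound 4 (1.27 log units; beyond the scatter). All three steps run in the same direction and lie beyond the scatter, so among the four groups shown, hydroxy alone gives a clear loss at this place, whereas the earlier compounds differ by much less, only methyl to cyano lying beyond the scatter. No measurement available here accounts for this loss.

As far as these compounds go, it remains open whether an amine or a methoxy group at this place would follow hydroxy or stay with fluoro, methyl and cyano. Four compounds also cannot show whether a carboxylic acid or a longer chain here would be tolerated.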